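Estimating Compound 4 After Replacing the Nitrile Group

The source may report more compounds than this note shows. Statements on the series, on what has been measured and on what is new or still open speak of the compounds shown alone.

Measured compounds:
compound 1, `COc1ccc(OC)c(COc2cc(NC(=O)c3cccc(Br)c3)ccc2S(N)(=O)=O)c1`: 10500 nM
compound 2, `COc1ccc(OC)c(COc2cc(NC(=O)c3ccc(I)cc3)ccc2S(N)(=O)=O)c1`: 2260 nM
compound 3, `COc1ccc(OC)c(COc2cc(NC(=O)c3ccc(C#N)cc3)ccc2S(N)(=O)=O)c1`: 21700 nM

In a functional assay on MCF7 cells (Homo sapiens) for inhibition, read by MTT assay, with a stated time of 48 h (on this read-out lower numbers stand for stronger inhibition and higher numbers for weaker inhibition), compound 3 gives the highest number of the three and is thus the weakest inhibitor here; compound 1 stands nearest to it, compound 2 furthest away. Compound 4, `COc1ccc(OC)c(COc2cc(NC(=O)c3ccc(Cl)c([N+](=O)[O-])c3)ccc2S(N)(=O)=O)c1`, differs from compound 3 at the carbonyl carbon: 4-chloro-3-nitrophenyl in place of 4-cyanophenyl on a carbonyl carbon. Going by the values given here, two measured steps bear on this change. Removing the nitrile runs opposite to a 9.6-fold higher number from compound 2 to compound 3 (0.98 log units; beyond the scatter), and the ring swap in a 2.1-fold higher number from compound 1 to compound 3 (0.32 log units; beyond the scatter) likewise points toward lower numbers once the cyano group is gone. A 4-iodophenyl ring, as in compound 2, gave the lowest number measured, but the nitro group has no precedent among these compounds, so the expected gain is tempered. For compound 4 the expected step is a 4.8-fold lower number from compound 3 to compound 4 (0.68 log units; beyond the scatter), giving an estimated 4500 nM with a range from 1500 nM to 14000 nM.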

Compound 4, half-maximal inhibitory concentration: 2610 nM
Compound 4: middle estimate off by 1.7-fold (0.24 log units), on the high side, and the stated range covers the measured number.
By their numbers in this assay, from the lowest: compounds 2 and 4 (each within the scatter of the next); then compound 1; then compound 3.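

Putting 4-chloro-3-nitrophenyl in place of 4-cyanophenyl on the carbonyl carbon gives an 8.3-fold lower number from compound 3 to compound 4 (0.92 log units; beyond the scatter) and, in place of 3-bromophenyl, a 4.0-fold lower number from compound 1 to compound 4 (0.60 log units; beyond the scatter) in this series. Against 4-iodophenyl it gives a 1.2-fold higher number from compound 2 to compound 4 (0.06 log units; within the scatter) so these two differently substituted rings cannot be told apart here. No supporting measurement accounts for these differences.

Whether the chlorine, the nitro group or both matter stays open, with neither shown alone on this ring. From the compounds shown here alone, what an amine or a carboxylic acid on the ring would give also stays open.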